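Swapping the aryl group on a weak antiproliferative scaffold

A few compounds are considered here, and "the series" means these few. Any claim that something is new, unique, unknown or untested is made for them only; others in the source may bear on it.

Compound 2 `CN(c1cccc2c1CN(c1nc(Nc3ccc(C(F)(F)F)cc3)ncc1C(F)(F)F)C2)S(C)(=O)=O` was tested in a functional assay on A549 cells (Homo sapiens) for antiproliferative activity, read by spectrophotometry, with a stated time of 2 days; on this read-out higher numbers stand for weaker inhibition of growth and lower numbers for stronger inhibition of growth. In this assay compound 2 reaches only the limit of > 30000 nM, so for it a limit and not a number is known. Compound 1 `CN(c1cccc2c1CN(c1nc(Nc3cc(C(F)(F)F)cc(C(F)(F)F)c3)ncc1C(F)(F)F)C2)S(C)(=O)=O` likewise stops at the limit of > 30000 nM in this assay. Compound 3 `COc1cc(Nc2ncc(C(F)(F)F)c(N3Cc4cccc(N(C)S(C)(=O)=O)c4C3)n2)cc(OC)c1` gives an actual number in this assay, 24800 nM, so the step of an at least 1.2-fold lower number from compound 2 to compound 3 (0.08 log units; that floor lies within the scatter) is only a floor that lies within the scatter. Two of the three values sit at the same limit, as the limit of > 30000 nM in this assay, at which 2 of the 3 values shown sit, shows.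

Compound 4 `COc1cc(Nc2ncc(C(F)(F)F)c(N3Cc4cccc(N(C)S(C)(=O)=O)c4C3)n2)c(OC)cc1Cl` differs from compound 2 by 4-chloro-2,5-dimethoxyphenyl in place of 4-(trifluoromethyl)phenyl on a nitrogen on an aromatic ring. Among the compounds with values here, only the step from compound 2 to compound 3 bears on it, and that step was small and bounded by a limit, so nothing beyond the scatter is expected in either direction. Compound 4 is therefore expected near 25000 nM in this assay, within 10000 nM to 60000 nM, with a real chance of a limit again. That estimate amounts to an expected step of an at least 1.2-fold lower number from compound 2 to compound 4 (0.07 log units; that floor lies within the scatter).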

Compound 4, concentration for 50% growth inhibition: 7300 nM
Estimate against measurement, compound 4: 3.4-fold (0.53 log units) above; measured number below the stated range.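

The aryl group on this nitrogen can clearly change growth inhibition: 4-chloro-2,5-dimethoxyphenyl in place of 3,5-dimethoxyphenyl gives a 3.4-fold lower number from compound 3 to compound 4 (0.53 log units; beyond the scatter) in this assay. Both of those compounds have measured numbers, so the size of this step is firm, and the two methoxy groups alone do not fix the result, since compound 3 and compound 4 both carry them. In place of 4-(trifluoromethyl)phenyl, the same group gives an at least 4.1-fold lower number from compound 2 to compound 4 (0.61 log units; beyond the scatter), and this is only a floor because compound 2 stands at a limit: the limit of > 30000 nM in this assay, at which 2 of the 4 values shown sit.

The compounds shown cannot separate the part played by the chlorine from that of the altered methoxy arrangement. On these data alone, it also remains open how a bromine in place of the chlorine, or an amine on this ring, would perform.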